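Trimethoxyphenyl benzimidazoles: the hydroxyl question on the pendant ring

The source may report more compounds than this note shows. Statements on the series, on what has been measured and on what is new or still open speak of the compounds shown alone.

Measured compounds:
compound 1 `COc1ccc(-c2ccc3ncn(-c4cc(OC)c(OC)c(OC)c4)c3c2)cc1O`, 44 nM
compound 2 `COc1cc(-n2cnc3ccc(-c4cccc(O)c4)cc32)cc(OC)c1OC`, 53 nM
compound 3 `COc1cc(-n2cnc3ccc(-c4ccc(Cl)cc4)cc32)cc(OC)c1OC`, 1270 nM

In a functional assay on SGC-7901 cells (Homo sapiens) for antiproliferative activity, read by MTT assay, with a stated time of 72 h (on this read-out higher numbers stand for weaker inhibition and lower numbers for stronger inhibition), compound 1 gives 44 nM, the lowest of the three numbers; compound 2 sits closest to it, and compound 3 furthest away. The step of a 1.2-fold higher number from compound 1 to compound 2 (0.08 log units; within the scatter) shows that dropping the methoxy from the pendant ring leaves the result essentially unchanged. By contrast, a 29-fold higher number from compound 1 to compound 3 (1.46 log units; beyond the scatter) and a 24-fold higher number from compound 2 to compound 3 (1.38 log units; beyond the scatter) show that swapping the hydroxyl-bearing rings for a 4-chlorophenyl costs a great deal.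

Compound 4 `COc1cccc(-c2ccc3ncn(-c4cc(OC)c(OC)c(OC)c4)c3c2)c1` has not yet been measured in this assay. Relative to compound 1 its change is 3-methoxyphenyl in place of 3-hydroxy-4-methoxyphenyl on an aromatic carbon. Here the methoxy is kept and the hydroxyl is removed, so the step is the mirror of the one from compound 1 to compound 2, and the two large steps to compound 3 indicate that the hydroxyl-bearing ring is where most of the potency resides. A loss beyond the scatter is therefore expected, but smaller than that seen for compound 3, since a single oxygen substituent remains on the pendant ring. Compound 4 is expected to give 160 nM, within 50 nM to 550 nM, corresponding to an estimated step of a 3.6-fold higher number from compound 1 to compound 4 (0.56 log units; beyond the scatter).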

Compound 4, half-maximal inhibitory concentration: 3310 nM
Compound 4: middle estimate off by 21-fold (1.32 log units), on the low side; measured number above the stated range.
By their numbers in this assay, from the lowest: compounds 1 and 2 (each within the scatter of the next); then compound 3; then compound 4.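

In this assay, methyl in place of hydrogen on the oxygen of the 3-hydroxyphenyl ring gives a 62-fold higher number from compound 2 to compound 4 (1.80 log units; beyond the scatter), whereas removing the methoxy had stayed within the scatter, so among these compounds the result at this position follows the free hydroxyl and not the mere presence of an oxygen substituent. The same holds when the 3-hydroxy-4-methoxyphenyl ring gives way to 3-methoxyphenyl, with a 75-fold higher number from compound 1 to compound 4 (1.88 log units; beyond the scatter), which is again a large step and shows that the methoxy left on the ring does not make up for the lost hydroxyl. The 3-methoxyphenyl ring also falls behind 4-chlorophenyl, with a 2.6-fold higher number from compound 3 to compound 4 (0.42 log units; beyond the scatter), a modest step, so the retained oxygen substituent brings no advantage over the chlorine-bearing ring.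

Nothing available here accounts for the size of these losses. The compounds shown leave open whether an amino or hydroxymethyl group could stand in for the hydroxyl on the pendant ring, and whether an ethoxy group would behave as the methoxy does.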